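This account rests on a few compounds, and the source may have more. Where it says the series, first, only, none or still open, it means among the compounds named here.

Measured compounds:
Compound 1 `CCNC(=O)c1oc2nc(-c3ccccc3)cc(C(F)(F)F)c2c1N` — 42800 nM
Compound 2 `CNC(=O)c1oc2nc(-c3cccs3)cc(C(F)(F)F)c2c1N` — 12300 nM

Both numbers come from a functional assay on HepG2 cells (Homo sapiens) for antiproliferative activity, read by MTT assay; a higher number here means a weaker inhibitor, a lower number a stronger inhibitor. Compound 2 stands at the lower of the two values, with compound 1 the nearest neighbour at a gap that lies beyond the scatter. Going by the values given here, compound 1 and compound 2 differ in two places at once, in the aryl group and in the amide substituent, so no single step between them can be read from this pair.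

Compound 3 `CCNC(=O)c1oc2nc(-c3cccs3)cc(C(F)(F)F)c2c1N` takes the step from compound 2 of methyl in place of hydrogen on a saturated chain carbon bound to an amide-type nitrogen. Among the compounds with values here, no measured pair in this set shows that change on its own, so its size is unknown here. For a difference of this kind, a single added carbon on the amide substituent, no step beyond the scatter is expected in this assay, in either direction.

Compound 3 is therefore estimated at 15000 nM, within a range of 6000 nM to 40000 nM, which corresponds to an expected step of a 1.2-fold higher number from compound 2 to compound 3 (0.09 log units; within the scatter) from the value of compound 2.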

Compound 3, half-maximal inhibitory concentration: 12100 nM
The estimate for compound 3 lay 1.2-fold (0.09 log units) above the measured number; low and high end bracket the measured number.
By their numbers in this assay, from the lowest: compounds 3 and 2 (each within the scatter of the next); then compound 1.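

In this assay, methyl in place of hydrogen on a saturated chain carbon bound to an amide-type nitrogen gives a 1.0-fold lower number from compound 2 to compound 3 (0.01 log units; within the scatter) with thiophen-2-yl held fixed, so methylcarbamoyl and ethylcarbamoyl cannot be told apart at this position in this read-out. The two differences carried together by the earlier pair can now be separated: with ethylcarbamoyl held fixed, thiophen-2-yl in place of phenyl on an aromatic carbon gives a 3.5-fold lower number from compound 1 to compound 3 (0.55 log units; beyond the scatter) as a modest step beyond the scatter, and it is the only one of the two changes shown to exceed the scatter in this small set.

Going by these compounds, whether methylcarbamoyl and ethylcarbamoyl also stay within the scatter of each other with phenyl as the aryl group remains open. On these data alone, it is equally open whether a longer chain such as propyl, or a chain ending in an amine or a carboxylic acid, would leave the number where it stands or move it, and whether aryl groups such as furan-2-yl or pyridin-2-yl would extend the step seen with thiophen-2-yl. No supporting measurement is available to explain either step.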